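Acetyl in Place of tert-Butyl: An Expected Inhibition Value

The source may report more compounds than this note shows. Statements on the series, on what has been measured and on what is new or still open speak of the compounds shown alone.

Compound 2 `CC(C)(C)c1ccc(Nc2ccc3c(c2)C(=O)N(C2CCC(=O)NC2=O)C3=O)cc1` stands, in an assay on FRT-Jurkat cells for inhibition of nuclear factor NF-kappa-B complex (Homo sapiens), read by flow cytometry, with a stated time of 24 h, tested at 10 uM (a lower number here means less inhibition, a higher number more inhibition at the concentration tested (going by the name of the read-out)), at 17%. Compound 3 `CCc1ccc(Nc2cccc3c2C(=O)N(C2CCC(=O)NC2=O)C3=O)cc1` gives 17% in this assay, level with compound 2 at the digits reported, and compound 1 `Cc1ccccc1Nc1cccc2c1C(=O)N(C1CCC(=O)NC1=O)C2=O` gives 7%, within the scatter of both. The only single-place step among these, a number 10 percentage points higher from compound 1 to compound 3 (within the scatter), alters the group on the nitrogen and lies within the scatter. Compound 4 `CC(=O)c1ccc(Nc2ccc3c(c2)C(=O)N(C2CCC(=O)NC2=O)C3=O)cc1` differs from compound 2 by acetyl in place of tert-butyl on an aromatic carbon. Among the compounds with values here, no measured step touches a change of this kind on the aromatic carbon, so nothing in the data argues for movement beyond the scatter in this assay. Compound 4 is therefore expected to give 15%, within 3% to 30%. The step of a number 2 percentage points lower from compound 2 to compound 4 (within the scatter) is estimated to stay within the scatter.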

Compound 4, a percentage reported as inhibition, at one concentration (the size of the read-out at that concentration, not a potency): -2%
The estimate for compound 4 lay 17 percentage points above the measured number; measured number outside the range, below it.
By their numbers in this assay, from the lowest: compounds 4, 1, 2 and 3 (each within the scatter of the next, the first and the last beyond it).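

Going from tert-butyl to acetyl on this aromatic carbon gives a number 19 percentage points lower from compound 2 to compound 4 (beyond the scatter) in this assay and is the first step among these compounds to leave the scatter, so the read-out does respond to the group held at this position, para to a large group. Within the data shown here, the change removes one heavy atom and adds a hydrogen-bond acceptor and a double bond, and the single step cannot separate these differences. No measurement shown accounts for the step. Still open, going by these compounds, is whether an amine or a carboxylic acid on this carbon would read like acetyl or like tert-butyl.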